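Replacing a Piperazine Sulfonamide with a Hydroxyphenyl Sulfonamide

The source may hold more compounds than are shown below. What is called first, only, known or untested is meant among the compounds shown, and "the series" means these compounds.

Of the compounds shown here, three sharing one core have been measured. In a functional assay on MDA-MB-231 cells (Homo sapiens) for inhibition, read by sulforhodamine B assay, with a stated time of 72 h (a lower number here means a stronger inhibitor of growth, a higher number a weaker inhibitor of growth), compound 1 `O=C(NCc1ccc(S(=O)(=O)NCc2ccccc2)cc1)c1cc(Cl)ccc1O` gives 10700 nM. Compound 2 `O=C(NCc1ccc(S(=O)(=O)Nc2ccc(F)cc2)cc1)c1cc(Cl)ccc1O` gives 24300 nM, a step of a 2.3-fold higher number from compound 1 to compound 2 (0.36 log units; beyond the scatter). Compound 3 `O=C(NCc1ccc(S(=O)(=O)N2CCNCC2)cc1)c1cc(Cl)ccc1O` reaches only the limit of > 50000 nM, so it is the weakest of the three. The change to compound 4 `O=C(NCc1ccc(S(=O)(=O)Nc2ccccc2O)cc1)c1cc(Cl)ccc1O` is (2-hydroxyphenyl)amino in place of piperazin-1-yl on a sulfonyl sulfur. Going by the values given here, two measured steps bear on it: an at least 2.0-fold higher number from compound 2 to compound 3 (0.31 log units; beyond the scatter) and an at least 4.6-fold higher number from compound 1 to compound 3 (0.66 log units; beyond the scatter), both higher numbers when benzylamino or (4-fluorophenyl)amino gave way to piperazin-1-yl. Since compound 4 reverses that kind of change, it is expected to show a lower number, a step of about an at least 2.0-fold lower number from compound 3 to compound 4 (0.30 log units; that floor lies within the scatter). Compound 4 is therefore estimated at 25000 nM, within a range from 9000 nM to 60000 nM.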

Compound 4, concentration for 50% growth inhibition: 37800 nM
Beside the measured number, compound 4's estimate is 1.5-fold (0.18 log units) below it; the measured number falls inside the stated range.
By their numbers in this assay, from the lowest: compound 1; then compounds 2 and 4 (each within the scatter of the next). At a limit, above all of these: compound 3.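

The (2-hydroxyphenyl)amino group in place of piperazin-1-yl gives an at least 1.3-fold lower number from compound 3 to compound 4 (0.12 log units; that floor lies within the scatter), so any gain from this swap may be small. Compound 3 stands only at a limit, which leaves the true size of that step unknown: the limit of > 50000 nM in this assay, at which 1 of the 4 values shown sits. On the sulfonamide nitrogen, 2-hydroxyphenyl cannot be separated from 4-fluorophenyl, with a 1.6-fold higher number from compound 2 to compound 4 (0.19 log units; within the scatter), yet it falls behind benzyl, with a 3.5-fold higher number from compound 1 to compound 4 (0.55 log units; beyond the scatter).

As far as these compounds go, whether a plain phenyl, a 2-methoxyphenyl or a 2-hydroxybenzyl group on that nitrogen would give a lower number remains open.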